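Removing the nitrile from a salicylanilide-type Jurkat cytotoxicity series

This account rests on a few compounds, and the source may have more. Where it says the series, first, only, none or still open, it means among the compounds named here.

Among the three measured compounds, compound 1 `N#Cc1cc(Cl)ccc1NC(=O)c1ccc2cccnc2c1O` gives the lowest number: in a functional assay on Jurkat cells (Homo sapiens) for cytotoxicity, read by luminescence and CellTiter-Glo, with a stated time of 3 days (a lower number here means a stronger inhibitor, a higher number a weaker inhibitor), compound 1 gives 170 nM. Compound 2 `O=C(Nc1cc(C(F)(F)F)cc(C(F)(F)F)c1)c1cc(Br)ccc1O` gives 350 nM, which lies beyond the scatter above compound 1, and compound 3 `O=C(Nc1ccc(C(F)(F)F)cc1)c1cc(Br)ccc1O` gives 620 nM, further still. Going by the values given here, compounds 2 and 3 share a different core from compound 1, so no single-change step links them to it.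

Compound 4 `O=C(Nc1ccc(Cl)cc1)c1ccc2cccnc2c1O` keeps the core of compound 1 and its chloro group and differs only in one place: hydrogen in place of cyano on an aromatic carbon. The cyano sits on an aromatic carbon of a six-membered aromatic ring of carbon only, ortho to a large group and meta to the chloro group.

Among the compounds with values here, no step between measured compounds speaks to this change. Because compound 1 already gives 170 nM, a modest loss is expected, with the step from compound 1 to compound 4 estimated at a 2.4-fold higher number from compound 1 to compound 4 (0.37 log units; beyond the scatter). Compound 4 is therefore expected to give about 400 nM in this assay, within a range from 150 nM to 1200 nM.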

Compound 4, half-maximal inhibitory concentration: 510 nM
Compound 4: middle estimate off by 1.3-fold (0.11 log units), on the low side, and the stated range covers the measured number.
By their numbers in this assay, from the lowest: compound 1; then compounds 2, 4 and 3 (each within the scatter of the next).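

Replacing the cyano on this aromatic carbon, ortho to a large group and meta to a chloro group, with hydrogen gives a 3.0-fold higher number from compound 1 to compound 4 (0.48 log units; beyond the scatter) in this assay, so this position affects the number measured on the core of compound 1. The loss is modest, and compound 4, which keeps the core and the chloro group, still gives 510 nM without the nitrile. No independent measurement among these results accounts for the size of this step.

The compounds shown leave open whether an amine, a carboxylic acid, a fluoro group or a methoxy group at this position would give a number nearer that of compound 1 or that of compound 4. They also leave open whether a nitrile on the aniline ring of compound 2 or compound 3 would produce a comparable step.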